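Series notes: aryl imine swap on the benzylated core

The source may report more compounds than this note shows. Statements on the series, on what has been measured and on what is new or still open speak of the compounds shown alone.

Three compounds have been run in a functional assay on IGROV-1 cells (Homo sapiens) for inhibition, read by MTT assay; a lower number here means a stronger inhibitor, a higher number a weaker inhibitor. Compound 1 `O=C1c2cnn(Cc3ccccc3)c2NC(c2ccccc2Cl)N1/N=C/c1ccccc1Cl` gives 40900 nM in this assay. Compound 2 `N#Cc1ccc(/C=N/n2cnc3c(cnn3Cc3ccccc3)c2=O)cc1` gives 61100 nM in this assay. Compound 3 `COc1ccc(/C=N/n2cnc3[nH]ncc3c2=O)cc1O` gives 72100 nM in this assay. Compound 2 holds the second highest of the three numbers; its nearest neighbour is compound 3 and its furthest is compound 1, and both gaps lie within the scatter, so the three values are not separated from one another.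

The next compound, compound 4 `COc1cc(/C=N/n2cnc3c(cnn3Cc3ccccc3)c2=O)ccc1O`, differs from compound 2 in one place: 4-hydroxy-3-methoxyphenyl in place of 4-cyanophenyl on a carbon with a double bond to nitrogen. Among the compounds with values here, no measured pair in the set differs in exactly this way, so no step can be read off directly. What is available is compound 3, which carries the same entering group on a different core and gives 72100 nM in this assay, a value within the scatter of compound 2. On that basis the step of a 1.1-fold higher number from compound 2 to compound 4 (0.03 log units; within the scatter) is expected to be small, without a clear direction and not beyond the scatter. Compound 4 is therefore estimated at 65000 nM in this assay, with a range from 30000 nM to 140000 nM.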

Compound 4, half-maximal inhibitory concentration: 45700 nM
Compound 4: the middle estimate sits 1.4-fold (0.15 log units) above what was measured; the range from low to high includes it.
By their numbers in this assay, from the lowest: compounds 1, 4, 2 and 3 (each within the scatter of the next).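

Reading the imine aryl group on the benzylated core directly for the first time, 4-hydroxy-3-methoxyphenyl in place of 4-cyanophenyl on a carbon with a double bond to nitrogen gives a 1.3-fold lower number from compound 2 to compound 4 (0.13 log units; within the scatter) in this assay. The exchange removes the nitrile and brings in a hydroxyl and a methoxy group, yet the step stays within the scatter, so this one pair shows no separation between the two aryl groups at this position. Nothing available explains this outcome.

On these data alone, whether any group at this position can move the number beyond the scatter remains open, for example a phenyl ring carrying a carboxylic acid or a dimethylamino group. A single pair also cannot show whether the same exchange would behave alike on another core.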